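Removing the chloro from the fused ring of compound 2

This account rests on a few compounds, and the source may have more. Where it says the series, first, only, none or still open, it means among the compounds named here.

Of the compounds shown here, three sharing one core have been measured in a functional assay on HeLa cells (Homo sapiens) for antiproliferative activity, read by MTT assay, with a stated time of 48 h; on this read-out higher numbers stand for weaker inhibition and lower numbers for stronger inhibition. Compound 1 `CS(=O)(=O)c1ccc(Nc2ncc(F)c(Nc3nc4ccccc4s3)n2)cc1` gives 3170 nM. Compound 2 `Cc1cnc(Nc2ccc(S(C)(=O)=O)cc2)nc1Nc1nc2ccc(Cl)cc2s1` gives 4180 nM. Compound 3 `Cc1ccc2nc(Nc3nc(Nc4ccc(S(N)(=O)=O)cc4)ncc3C)sc2c1` gives 3280 nM. Compound 2 holds the highest of the three numbers, yet its distance to compound 3 and to compound 1 stays within the usual scatter of repeated measurements, so no order among the three can be read from these values.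

Compound 4 `Cc1cnc(Nc2ccc(S(C)(=O)=O)cc2)nc1Nc1nc2ccccc2s1` has not yet been measured in this assay. It differs from compound 2 in one place: hydrogen in place of chloro on an aromatic carbon. Among the compounds with values here, no pair of measured compounds differing in one place is available to calibrate this change. Within the data shown here, the only guide is that compound 1, which also carries no substituent on that fused ring, gives 3170 nM, close to the values of the other two. Compound 4 is therefore expected to give 3500 nM, with a range from 1500 nM to 8000 nM. The step from compound 2 to compound 4 is estimated as a 1.2-fold lower number from compound 2 to compound 4 (0.08 log units; within the scatter), that is, no change beyond the scatter.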

Compound 4, half-maximal inhibitory concentration: 460 nM
For compound 4 the middle estimate is 7.6-fold (0.88 log units) above the measured one; measured number below the stated range.
By their numbers in this assay, from the lowest: compound 4; then compounds 1, 3 and 2 (each within the scatter of the next).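

Once the fused ring's chloro is replaced by hydrogen, the number in this assay falls with a 9.1-fold lower number from compound 2 to compound 4 (0.96 log units; beyond the scatter), so this aromatic carbon matters, which the three earlier values, all within the scatter of one another, could not show. On the other ring, methyl in place of fluoro gives a 6.9-fold lower number from compound 1 to compound 4 (0.84 log units; beyond the scatter), so the same compound 4 stands apart from both neighbours that differ from it in one place, and the lower number is seen only where hydrogen on the fused ring and methyl on the other ring occur together. The compounds shown offer no evidence on why either change has this effect.

As far as these compounds go, how a methoxy group or an amine on that aromatic carbon would compare with hydrogen and chloro remains open. So does whether an ethyl group or a plain hydrogen in place of the methyl would keep the lower number of compound 4.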